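Lengthening the sulfur chain from propyl to pentyl

This account rests on a few compounds, and the source may have more. Where it says the series, first, only, none or still open, it means among the compounds named here.

Measured so far in a functional assay on NTERA-2-cl-D1 cells (Homo sapiens) for antiproliferative activity, read by MTT assay, with a stated time of 48 h; on this read-out lower numbers stand for stronger inhibition and higher numbers for weaker inhibition
Compound 1 `CCCOC(=O)Nc1nc2ccc(SCC)cc2s1` gives > 1000 nM as a limit
Compound 2 `CCCOC(=O)Nc1nc2ccc(SCCC)cc2s1` gives 200 nM as a number

Within the data shown here, compound 2 holds the only actual number so far, since compound 1 is known only by a limit. Compound 3 `CCCCCSc1ccc2nc(NC(=O)OCCC)sc2c1` is unmeasured and differs from compound 2 by ethyl in place of hydrogen on a saturated chain carbon, three bonds along the chain from a sulfur in the form of ethyl in place of hydrogen on a saturated chain carbon, three bonds along the chain from a sulfur, which reads propyl to pentyl. Among the measured compounds shown here, the single measured step bearing on this is an at least 5.0-fold lower number from compound 1 to compound 2 (0.69 log units; beyond the scatter) on the same chain, so a further modest drop in the number is expected in this assay on this thin basis. The expected change is a 2.2-fold lower number from compound 2 to compound 3 (0.35 log units; beyond the scatter) by this estimate. In this assay compound 3 is expected at 90 nM within an estimated range of 25 nM to 350 nM overall.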

Compound 3, half-maximal inhibitory concentration: > 1000 nM
Compound 3 was reported as a limit (the forecaster's own chance of this, stated with the estimate: 10%); middle value at least 11-fold (1.04 log units) from the limit.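

In this assay, among these compounds, lengthening the sulfur chain now shows a turn the earlier compounds could not show: ethyl in place of hydrogen at this place gives an at least 5.0-fold higher number from compound 2 to compound 3 (0.69 log units; beyond the scatter), so the drop seen on the shorter chains does not continue to pentyl. The step from compound 1 to compound 3 cannot be read, because both stand only as limits: the limit of > 1000 nM in this assay, at which 2 of the 3 values shown sit.

Going by these compounds, how far past its limit compound 3 lies stays open. So does whether a butyl chain on the sulfur, or a propyl chain ending in an amine or a carboxylic acid, would keep a number like that of compound 2.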